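The source may report more compounds than this note shows. Statements on the series, on what has been measured and on what is new or still open speak of the compounds shown alone.

Values in a functional assay on SGC-7901 cells (Homo sapiens) for antiproliferative activity, read by MTT assay, with a stated time of 72 h (a higher number here means a weaker inhibitor, a lower number a stronger inhibitor), for the measured compounds:
compound 1 `COc1ccc(-c2cc(C(=O)O)sc2-c2cc(OC)c(OC)c(OC)c2)cc1` gives 4220 nM
compound 2 `COc1ccc(-c2cc(C(=O)O)sc2-c2cc(OC)c(OC)c(OC)c2)cc1[N+](=O)[O-]` gives 21600 nM
compound 3 `COc1ccc(-c2cc(C(=O)O)sc2-c2cc(OC)c(OC)c(OC)c2)cc1OCc1ccccc1` gives > 100000 nM as a limit

Compound 3 has no number and rests on the limit of > 100000 nM in this assay, at which 1 of the 3 values shown sits, alone. The next compound, compound 4 `COc1ccc(-c2cc(C(=O)O)sc2-c2cc(OC)c(OC)c(OC)c2)cc1O`, carries hydrogen in place of benzyl on an oxygen on an aromatic ring and so goes from benzyloxy to hydroxy. For the measured compounds named here, two measured steps bear on this: an at least 23-fold higher number from compound 1 to compound 3 (1.37 log units; beyond the scatter) is large and an at least 4.6-fold higher number from compound 2 to compound 3 (0.66 log units; beyond the scatter) points the same way. Both involve gaining the benzyloxy group, while a 5.1-fold higher number from compound 1 to compound 2 (0.71 log units; beyond the scatter) is a modest step. Losing the benzyl group should undo much of the rise seen in an at least 23-fold higher number from compound 1 to compound 3 (1.37 log units; beyond the scatter) and return the number toward those of the two measured compounds with a number. The change expected in this assay is an at least 12-fold lower number from compound 3 to compound 4 (1.09 log units; beyond the scatter) and would be a large fall in the number, toward a stronger inhibitor. Compound 4 is estimated at 8000 nM with an expected span from 2000 nM to 35000 nM as the likely range.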

Compound 4, half-maximal inhibitory concentration: 17500 nM
Compound 4: the middle estimate sits 2.2-fold (0.34 log units) below what was measured, within the range that was stated.
By their numbers in this assay, from the lowest: compound 1; then compounds 4 and 2 (each within the scatter of the next). At a limit, above all of these: compound 3.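

In this assay, replacing benzyloxy with hydroxy brings the series back to a measured number, an at least 5.7-fold lower number from compound 3 to compound 4 (0.75 log units; beyond the scatter), but hydroxy does not recover the value of the unsubstituted position, a 4.1-fold higher number from compound 1 to compound 4 (0.62 log units; beyond the scatter). Hydroxy and nitro on this aromatic carbon cannot be told apart, a 1.2-fold lower number from compound 2 to compound 4 (0.09 log units; within the scatter), so two different groups give the same level of activity here. Compound 3 rests on a limit, not a number: the limit of > 100000 nM in this assay, at which 1 of the 4 values shown sits.

Still open, from the compounds shown here alone, is whether any group on this aromatic carbon, such as an amine or a chlorine, gives a lower number than hydrogen. Also open, going by these compounds, is whether a small ether such as methoxy stays near hydroxy or moves toward benzyloxy.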